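A ring swap at compound 2

The compounds below may be only part of what the source reports. "The series", "measured", "known", "first", "only" and "open" are said of these compounds alone.

Compound 1 `O=C(O)c1cn(C2CC2)c2c(C(F)(F)F)c(N3CCNCC3)c(F)cc2c1=O` gives 1650 ug/mL
Compound 2 `NC1CCN(c2c(F)cc3c(=O)c(C(=O)O)cn(C4CC4)c3c2C(F)(F)F)CC1` gives 20 ug/mL

In a functional assay on V79 cells (Cricetulus griseus) for cytotoxicity, read by colony formation (a higher number here means a weaker inhibitor, a lower number a stronger inhibitor), compound 2 holds the lower of the two numbers (20 ug/mL). Compound 3 `CC1(N)CCN(c2c(F)cc3c(=O)c(C(=O)O)cn(C4CC4)c3c2C(F)(F)F)C1` carries 3-amino-3-methylpyrrolidin-1-yl in place of 4-aminopiperidin-1-yl on an aromatic carbon of the shared core (3-amino-3-methylpyrrolidin-1-yl in place of 4-aminopiperidin-1-yl on an aromatic carbon). For the measured compounds named here, only one measured step bears on this (an 83-fold lower number from compound 1 to compound 2 (1.92 log units; beyond the scatter)). It was large, and it exchanged piperazin-1-yl for 4-aminopiperidin-1-yl on that carbon. Going by the values given here, no measured compound carries a five-membered ring there, so the range stays wide. A slightly higher number is expected (a 1.5-fold higher number from compound 2 to compound 3 (0.18 log units; within the scatter)), with no step beyond the scatter. The estimated value for compound 3 is 30 ug/mL (expected range 6 ug/mL to 200 ug/mL).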

Compound 3, half-maximal inhibitory concentration: 110 ug/mL
Compound 3: the middle estimate sits 3.7-fold (0.56 log units) below what was measured; the range from low to high includes it.
By their numbers in this assay, from the lowest: compound 2; then compound 3; then compound 1.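

Exchanging 4-aminopiperidin-1-yl for 3-amino-3-methylpyrrolidin-1-yl at this aromatic carbon keeps the same atoms, yet in this assay it gives a 5.5-fold higher number from compound 2 to compound 3 (0.74 log units; beyond the scatter), so how those atoms are joined matters, not only which atoms they are. The five-membered group still keeps much of the gain over piperazin-1-yl, with a 15-fold lower number from compound 1 to compound 3 (1.18 log units; beyond the scatter) in the same assay. No measurement at hand gives a reason for either step. Going by these compounds, the swap changes ring size and adds a methyl group at once, so their separate shares stay unknown. 3-aminopyrrolidin-1-yl, without the methyl, would divide them.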